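The source may report more compounds than this note shows. Statements on the series, on what has been measured and on what is new or still open speak of the compounds shown alone.

Measured so far:
- compound 1, `COc1cccc(NC(=O)Nc2ccc(Oc3ncnc4[nH]ncc34)cc2)c1`: 82000 nM in an assay on isolated protein for inhibition of vascular endothelial growth factor receptor 2 (Danio rerio), read by fluorescence and microscopy, with a stated time of 33 h; a lower number here means a stronger inhibitor, a higher number a weaker inhibitor
- compound 2, `O=C(Nc1ccc(Oc2ncnc3[nH]ncc23)cc1)Nc1cccnc1`: a limit only

Compound 2 in this assay reaches only the assay limit, > 100000 nM, and gives no number. Within the data shown here, compound 2 thus sits at the limit of > 100000 nM in this assay, at which 1 of the 2 values shown sits, and the one step touching it, an at least 1.2-fold higher number from compound 1 to compound 2 (0.08 log units; that floor lies within the scatter), is a floor that lies within the usual scatter.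

The next compound, compound 3 `CC(C)c1cccc(NC(=O)Nc2ccc(Oc3ncnc4[nH]ncc34)cc2)c1`, differs from compound 2 by 3-isopropylphenyl in place of pyridin-3-yl on an amide-type nitrogen. Among the measured compounds shown here, no measured step changes an aryl group on that amide-type nitrogen for a carbon-only ring, so the only guide is that compound 1, which also carries a substituted phenyl there, gives 82000 nM in this assay. From the pyridin-3-yl of compound 2 back to a carbon-only ring, a step of about an at least 1.2-fold lower number from compound 2 to compound 3 (0.09 log units; that floor lies within the scatter) in this assay is therefore expected, though a result at the limit remains possible.

For compound 3 the expected value in this assay is 80000 nM, with a range from 25000 nM to 250000 nM.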

Compound 3, half-maximal inhibitory concentration: 7730 nM
Beside the measured number, compound 3's estimate is 10-fold (1.01 log units) above it; measured number outside the range, below it.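

In this assay, the substituent on the phenyl ring at the amide-type nitrogen matters: isopropyl in place of methoxy on an aromatic carbon gives an 11-fold lower number from compound 1 to compound 3 (1.03 log units; beyond the scatter), so these two substituted phenyl groups are not interchangeable at this place. The change from pyridin-3-yl to 3-isopropylphenyl gives an at least 12-fold lower number from compound 2 to compound 3 (1.11 log units; beyond the scatter), which is beyond the scatter even though the size of the step is only a floor. It can be read only as a floor because compound 2 has a limit and not a number: the limit of > 100000 nM in this assay, at which 1 of the 3 values shown sits.

On these data alone, whether the lower number is specific to isopropyl stays open, since an unsubstituted phenyl, a tert-butyl or a trifluoromethyl group in its place would be needed to show this. Also open, as far as these compounds go, is how an amine or a carboxylic acid on that ring would read in this assay.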